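The compounds below may be only part of what the source reports. "The series", "measured", "known", "first", "only" and "open" are said of these compounds alone.

Measured so far in an ADME assay on HCT-116 cells (Homo sapiens) for cytotoxicity, read by MTT assay, with a stated time of 72 h; on this read-out lower numbers stand for stronger inhibition and higher numbers for weaker inhibition:
compound 1 `Cc1ccc(N2C(=O)C/C(=C\c3cccc(C(=O)Nc4cccc(F)c4)c3)C2=O)cc1` gives > 100000 nM
compound 2 `CCCCCN1C(=O)C/C(=C\c2cccc(C(=O)Nc3cccc(CC)c3)c2)C1=O` gives 75300 nM
compound 3 `Cc1ccc(N2C(=O)C/C(=C\c3cccc(C(=O)Nc4ccc(Cl)cc4)c3)C2=O)cc1` gives > 100000 nM

The value of compound 3 is a limit of this assay and not a number. The value of compound 1 is likewise a limit. Two of the three values sit at the limit of > 100000 nM in this assay, at which 2 of the 3 values shown sit. Among the measured compounds shown here, the only step that changes a single place, a step that the two limits leave unreadable from compound 1 to compound 3, runs from one limit to another and so has no readable size. For the measured compounds named here, compound 2 is the only compound with a number; it differs from compound 3 in more than one place, so no single step connects the two, and their values show only that a compound carrying the 3-ethylphenyl amide can fall inside the measurable range.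

Compound 4 `CCc1cccc(NC(=O)c2cccc(/C=C3\CC(=O)N(c4ccc(C)cc4)C3=O)c2)c1` is still to be measured. The change from compound 3 is 3-ethylphenyl in place of 4-chlorophenyl on an amide-type nitrogen. Going by the values given here, the one step that bears on it, the step from compound 1 to compound 3, gives no size, so no direction can be read from the measured compounds. Compound 4 is expected to stay close to where compound 3 stands, with a number no higher from compound 3 to compound 4 (the limit leaves the size open) expected to be no step beyond the scatter. For compound 4 in this assay the estimate is 100000 nM, between 40000 nM and 300000 nM, with a fair chance that only a limit is reported.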

Compound 4, half-maximal inhibitory concentration: 41500 nM
Compound 4: the middle estimate sits 2.4-fold (0.38 log units) above what was measured; low and high end bracket the measured number.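

In this assay, 3-ethylphenyl in place of 4-chlorophenyl on the amide nitrogen gives an at least 2.4-fold lower number from compound 3 to compound 4 (0.38 log units; beyond the scatter), and ethyl in place of fluoro on an aromatic carbon gives an at least 2.4-fold lower number from compound 1 to compound 4 (0.38 log units; beyond the scatter), so this amide substituent now brings a number out of the limit on the core carrying 4-methylphenyl. With the 3-ethylphenyl amide held constant, 4-methylphenyl in place of pentyl on the ring nitrogen gives a 1.8-fold lower number from compound 2 to compound 4 (0.26 log units; within the scatter), so that change does not separate the two compounds. The values of compound 1 and compound 3 are limits of the assay, and the full size of both steps from them stays open: the limit of > 100000 nM in this assay, at which 2 of the 4 values shown sit.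

On these data alone, whether a longer chain than ethyl on the amide phenyl ring carries the number further remains open. So does the effect of an amine or a carboxylic acid at that place.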